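Trimming the Side Chain of an Aryltriazene

The source may hold more compounds than are shown below. What is called first, only, known or untested is meant among the compounds shown, and "the series" means these compounds.

Three aryltriazenes have been measured in a physicochemical assay for metabolic stability, read by HPLC, in phosphate buffer, at pH 7.7; on this read-out higher numbers stand for a longer-lived compound and lower numbers for a shorter-lived compound. Compound 1 `CC(=O)N[C@@H](C)C(=O)N(C)/N=N/c1ccc(Br)cc1` gives 25.5 h. Compound 2 `CCOC(=O)c1ccc(/N=N/N(C)C(=O)[C@H](C)NC(C)=O)cc1` gives 15.7 h. Within the data shown here, the one step between two compounds that differ in a single place, a 1.6-fold lower number from compound 1 to compound 2 (0.21 log units; within the scatter), stays within the scatter, so those two numbers cannot be told apart. Compound 3 `CCC(=O)N[C@@H](C)C(=O)N(C)/N=N/c1ccc(C#N)cc1` gives 10.1 h, the lowest of the three numbers; it lies within the scatter of compound 2 but beyond the scatter of compound 1, so it is shorter-lived than compound 1.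

Compound 4 `CC(=O)NCC(=O)N(C)/N=N/c1ccc(C#N)cc1` has not yet been measured. It differs from compound 3 on a carbonyl carbon whose other neighbours are an amide-type nitrogen: a group of 5 heavy atoms (3 carbon, 1 nitrogen, 1 oxygen; no ring) in place of a group of 7 heavy atoms (5 carbon, 1 nitrogen, 1 oxygen; no ring), on a carbonyl carbon. The aromatic nitrile and the triazene are kept.

Among the measured compounds shown here, no measured step bears on this part of the molecule: the only step on record changes a substituent on the aromatic ring, not the amide side chain. The expectation therefore rests on compound 3 alone, whose value 10.1 h is the anchor, and no step beyond the scatter is expected in this assay, so a 1.0-fold lower number from compound 3 to compound 4 (0.00 log units; within the scatter) is the estimated step. Compound 4 is expected to give 10 h, with a range from 5 h to 20 h.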

Compound 4, half-life: 7.6 h
Compound 4: middle estimate off by 1.3-fold (0.12 log units), on the high side; the range from low to high includes it.
By their numbers in this assay, from the lowest: compounds 4, 3, 2 and 1 (each within the scatter of the next, the first and the last beyond it).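

Among these compounds, this is the first step on record that touches the amide side chain rather than the aromatic ring. In this assay the acetamidomethyl group in place of the group of 7 heavy atoms gives a 1.3-fold lower number from compound 3 to compound 4 (0.12 log units; within the scatter) and so leaves the two compounds indistinguishable, which means that with the nitrile kept, this side chain can go down to 5 heavy atoms and lose its defined stereocentre without a difference the half-life can resolve. No measurement at hand accounts for this outcome.

The single step shortens the chain and removes the stereocentre together, so the compounds shown cannot separate these two parts of the change, and they do not show whether the same trimming would read alike with bromo or ethoxycarbonyl on the aromatic ring. Also open, on these data alone, is how far this tolerance extends on the carbonyl carbon, for instance to a longer chain or to a side chain ending in an amine or a carboxylic acid.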